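Tetrazole for carboxy along the ketone side chain

The compounds below may be only part of what the source reports. "The series", "measured", "known", "first", "only" and "open" are said of these compounds alone.

Compound 1 `CCCc1c(COc2ccc(C(=O)CCC(=O)O)cc2)ccc(C(C)=O)c1O` carries carboxy on a saturated chain carbon, two bonds along the chain from a carbonyl carbon. In a functional assay on ileum (Cavia porcellus) with cysteinyl leukotriene receptor (Homo sapiens) as the target (a lower number here means a less potent compound, a higher number a more potent compound, by a factor of ten per unit of this negative logarithm), compound 1 gives 6.75. Compound 2 `CCCc1c(COc2ccc(C(=O)CCc3nnn[nH]3)cc2)ccc(C(C)=O)c1O` differs from compound 1 by 1H-tetrazol-5-yl in place of carboxy on a saturated chain carbon, two bonds along the chain from a carbonyl carbon; in this assay compound 2 gives 7.09, a step of a number 0.34 log units higher from compound 1 to compound 2 (beyond the scatter). Among the measured compounds shown here, this is the one measured instance of that change.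

Compound 3 `CCCc1c(COc2ccc(C(=O)CCCC(=O)O)cc2)ccc(C(C)=O)c1O` is the second core. Its difference from compound 1 is carboxymethyl in place of carboxy on a saturated chain carbon, two bonds along the chain from a carbonyl carbon. In this assay compound 3 gives 6.81, with a step of a number 0.06 log units higher from compound 1 to compound 3 (within the scatter). Between compound 2 and compound 3 the step is a number 0.28 log units lower from compound 2 to compound 3 (within the scatter).

Compound 4 `CCCc1c(COc2ccc(C(=O)CCCc3nnn[nH]3)cc2)ccc(C(C)=O)c1O` has not been measured. It differs from compound 3 by 1H-tetrazol-5-yl in place of carboxy on a saturated chain carbon, three bonds along the chain from a carbonyl carbon. This is the same kind of change as that from compound 1 to compound 2, but the place differs: there the group sits on a saturated chain carbon two bonds along the chain from a carbonyl carbon, here three bonds along the chain from a carbonyl carbon. In this assay the step from compound 3 to compound 4 is expected to be a number 0.34 log units higher from compound 3 to compound 4 (beyond the scatter), set beside the measured a number 0.34 log units higher from compound 1 to compound 2 (beyond the scatter), and rests only on that single earlier step and on the values of compound 1 and compound 3 lying within the scatter of each other. Compound 4 is therefore estimated at 7.15 in this assay, with a range from 6.75 to 7.55.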

Compound 4, negative logarithm of the antagonist equilibrium constant: 7.67
For compound 4 the middle estimate is 0.52 log units below the measured one; measured number outside the range, above it.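

In this assay, 1H-tetrazol-5-yl in place of carboxy gives a higher number on both cores, so the direction of the change carries over from one core to the other, but its size does not: the same change on two cores in this assay, a number 0.34 log units higher (beyond the scatter) from compound 1 to compound 2 and a number 0.86 log units higher (beyond the scatter) from compound 3 to compound 4, 0.52 log units apart, beyond the scatter of two such steps

The chain matters only with the tetrazole present: (1H-tetrazol-5-yl)methyl in place of 1H-tetrazol-5-yl gives a number 0.58 log units higher from compound 2 to compound 4 (beyond the scatter), while the matching carboxy pair shows a number 0.06 log units higher from compound 1 to compound 3 (within the scatter). 1H-tetrazol-5-yl in place of carboxy on a saturated chain carbon, three bonds along the chain from a carbonyl carbon, gives a number 0.86 log units higher from compound 3 to compound 4 (beyond the scatter), and the full change from the shorter carboxy chain gives a number 0.92 log units higher from compound 1 to compound 4 (beyond the scatter). Compound 4 is thus the most potent of the four. These are single pairs on two cores, so they show that the size of the step differs between the place two bonds and the place three bonds along the chain from a carbonyl carbon, but they give neither a reason for that difference nor a rule for any further core.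

Going by these compounds, whether the step keeps growing on a longer chain ending in 1H-tetrazol-5-yl or in carboxy remains open. Also open, on these data alone, is how a sulfonic acid or an acyl sulfonamide at the end of the same chains would compare with these two groups.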